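This account rests on a few compounds, and the source may have more. Where it says the series, first, only, none or still open, it means among the compounds named here.

Compound 1 `ClCc1ccccc1Cn1cnc2c(Cl)nc(Cl)nc21`: 150 nM
Compound 2 `ClCc1ccccc1Cn1cnc2c(Cl)ncnc21`: 1200 nM
Compound 3 `ClCc1ccccc1Cn1cnc2ncnc(Cl)c21`: 2230 nM

Of the compounds shown here, three sharing one core have been measured in a functional assay on K562 cells (Homo sapiens) for cytotoxicity, read by sulforhodamine B assay, with a stated time of 48 h; on this read-out lower numbers stand for stronger inhibition of growth and higher numbers for weaker inhibition of growth. Compound 2 gives 1200 nM, the second highest of the three numbers. Its nearest neighbour is compound 3 with 2230 nM, and these two lie within the scatter of each other, so no order between them can be claimed. Furthest from it is compound 1 with 150 nM; the step of an 8.0-fold higher number from compound 1 to compound 2 (0.90 log units; beyond the scatter) is the only measured single-point step, and it lies beyond the scatter.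

Compound 4 `Nc1nc(Cl)c2ncn(Cc3ccccc3CCl)c2n1` has not yet been measured. Set against compound 2, the change is amino in place of hydrogen on an aromatic carbon. Among the measured compounds shown here, the one measured step that bears on it is an 8.0-fold higher number from compound 1 to compound 2 (0.90 log units; beyond the scatter), in which a substituent on an aromatic carbon of the core gave way to hydrogen and the number rose modestly. The change to compound 4 runs the other way, putting a substituent where hydrogen stood, though the entering group is not the same, so the measured step cannot simply be carried over. A modest fall in the number in this assay is therefore expected. Compound 4 is estimated to give 500 nM, with a range from 150 nM to 1500 nM. This expectation corresponds to the step of a 2.4-fold lower number from compound 2 to compound 4 (0.38 log units; beyond the scatter).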

Compound 4, concentration for 50% growth inhibition: 4470 nM
Compound 4: the middle estimate sits 8.9-fold (0.95 log units) below what was measured, outside the stated range (above it).
By their numbers in this assay, from the lowest: compound 1; then compounds 2, 3 and 4 (each within the scatter of the next, the first and the last beyond it).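

In this assay the carbon between two ring nitrogen atoms has now carried three different groups, and the new result shows that filling it does not by itself lower the number. Amino in place of hydrogen gives a 3.7-fold higher number from compound 2 to compound 4 (0.57 log units; beyond the scatter), the same direction as the loss of chloro. Amino in place of chloro gives a 30-fold higher number from compound 1 to compound 4 (1.47 log units; beyond the scatter), so the outcome at this carbon depends on which group enters, and of the two groups compared with hydrogen only chloro goes with a lower number. No available evidence accounts for this difference between the two groups. From the compounds shown here alone, whether a fluoro, bromo or methoxy group at this carbon would follow chloro or amino remains open. So does whether a methylamino or dimethylamino group would behave like amino itself.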